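This account rests on a few compounds, and the source may have more. Where it says the series, first, only, none or still open, it means among the compounds named here.

In an in vivo functional assay on the whole organism for inhibition of 3-hydroxy-3-methylglutaryl-coenzyme A reductase (Rattus norvegicus), at a dose of 2 mg/kg by the oral route (a lower number here means a weaker effect, a higher number a stronger effect of the compound at the dose given), compound 1 `Cc1nn(C(C)(C)C)c2nc(C3CC3)c(/C=C/[C@@H](O)C[C@@H](O)CC(=O)O)c(-c3ccc(F)cc3)c12` gives 72.2% and compound 2 `Cc1nn(C(C)(C)C)c2nc(C(C)C)c(/C=C/[C@@H](O)C[C@@H](O)CC(=O)O)c(-c3ccc(F)cc3)c12` gives 86%. The change between them is isopropyl in place of cyclopropyl on an aromatic carbon, and it produced a number 13.8 percentage points higher from compound 1 to compound 2 (beyond the scatter). Compound 3 `Cc1cc2nc(C3CC3)c(/C=C/[C@@H](O)C[C@@H](O)CC(=O)O)c(-c3ccc(F)cc3)n2n1` rests on a different core; how its core differs from that of compound 1 is not broken down here. In this assay compound 3 gives 6.5%, far under both others. Compound 4 `Cc1cc2nc(C(C)C)c(/C=C/[C@@H](O)C[C@@H](O)CC(=O)O)c(-c3ccc(F)cc3)n2n1` is made from compound 3 by isopropyl in place of cyclopropyl on an aromatic carbon, the same kind of change as from compound 1 to compound 2, though here the six-membered aromatic ring holds 2 nitrogen, the site is ortho to a large group and opposite the ring nitrogen. In this assay compound 4 is expected to give 16%, between 3% and 40%, that is an estimated a number 9.5 percentage points higher from compound 3 to compound 4 (within the scatter), because the earlier step of a number 13.8 percentage points higher from compound 1 to compound 2 (beyond the scatter) was modest and the starting point in compound 3 is low.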

Compound 4, a percentage reported as inhibition, in the whole organism at one dose (the size of the read-out at that dose, not a potency): -45.1%
The estimate for compound 4 lay 61.1 percentage points above the measured number, and the stated range ends above it.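

Isopropyl in place of cyclopropyl on an aromatic carbon gave a number 51.6 percentage points lower from compound 3 to compound 4 (beyond the scatter) in this assay. Set beside the earlier step, the same change did not carry from one core to the other, in either direction or size: the same change on two cores in this assay, a number 13.8 percentage points higher (beyond the scatter) from compound 1 to compound 2 and a number 51.6 percentage points lower (beyond the scatter) from compound 3 to compound 4, 65.4 percentage points apart, beyond the scatter of two such steps

This shows that, for these two cores, the outcome of the change depends on the core it is made on, but it does not show which feature of the cores is responsible, and these are read-outs at one dose, not potencies.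

The compounds shown leave open how a smaller chain such as ethyl or a group such as methoxy would behave at this place on each core. They also leave open which of the two outcomes a third core would follow.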